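This account rests on a few compounds, and the source may have more. Where it says the series, first, only, none or still open, it means among the compounds named here.

Measured compounds:
compound 1 `C=CCc1cc(C(C)=O)c(O)cc1OCC#N`: 2%
compound 2 `C=CCc1cc(C(C)=O)c(O)cc1OCCCCCCCC#N`: 52%
compound 3 `CCc1cc(C(C)=O)c(O)cc1OCCCCCC(C)(C)C(=O)O`: 73%

All three were tested in an assay on isolated protein for binding affinity to leukotriene B4 receptor 1 (Homo sapiens), tested at 1 uM; on this read-out lower numbers stand for less inhibition and higher numbers for more inhibition at the one concentration tested (going by the name of the read-out). Among these three numbers compound 2 stands second highest. Its nearest neighbour is compound 3, whose number lies higher by a margin beyond the usual scatter of repeated measurements; the furthest is compound 1, whose number lies lower, again beyond the scatter. No two of the measured compounds differ in just one place, so no single change has yet been isolated.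

Compound 4 `C=CCc1cc(C(C)=O)c(O)cc1OCCCCCC(C)(C)O` has not been measured. Set against compound 2, the change is 1-hydroxy-1-methylethyl in place of 2-cyanoethyl on a saturated chain carbon, five bonds along the chain from an oxygen on an aromatic ring. The nitrile is given up and a hydroxyl-bearing group arrives at the end of the chain. Among the compounds with values here, nothing among the measured pairs isolates this change, so the expectation rests on compound 3, which also ends its chain in an oxygen-containing group and gives 73% in this assay. On that basis the step from compound 2 to compound 4 is expected to be small and upward, a number 6 percentage points higher from compound 2 to compound 4 (within the scatter), possibly within the scatter. Compound 4 is therefore estimated at 58% in this assay, in a range from 32% to 80%.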

Compound 4, a percentage reported as inhibition, at one concentration (the size of the read-out at that concentration, not a potency): 60%
Compound 4: the middle estimate sits 2 percentage points below what was measured; measured number inside the range.
By their numbers in this assay, from the lowest: compound 1; then compounds 2 and 4 (each within the scatter of the next); then compound 3.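

Within the data shown here, this is the first pair in the set that differs in one place, so one change can now be read on its own: in this assay, putting 1-hydroxy-1-methylethyl in place of 2-cyanoethyl, on a saturated chain carbon five bonds along the chain from an oxygen on an aromatic ring, gives a number 8 percentage points higher from compound 2 to compound 4 (within the scatter). The two groups have the same number of heavy atoms, but the nitrile with its triple bond gives way to a hydroxyl-bearing group that adds a hydrogen-bond donor, and this swap leaves the read-out within the scatter, so the nitrile is not required at this chain end for inhibition at the one concentration tested. Nothing available explains why these two chain ends read alike.

On these data alone, whether an amine or a primary amide at the same chain end would also read alike remains open. As far as these compounds go, compound 3 differs from compound 4 in more than one place, so the part played by its carboxylic acid also remains open, and a direct swap of the hydroxyl-bearing group for a carboxylic acid on the core of compound 4 would be needed to isolate it.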